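Methyl to trifluoromethyl on the aryl group in a quinazolinone-free set

This account rests on a few compounds, and the source may have more. Where it says the series, first, only, none or still open, it means among the compounds named here.

Of the compounds shown here, three of the shared core have been tested in an assay on isolated protein for inhibition of DNA topoisomerase 1 (Homo sapiens), with a stated time of 30 min, tested at 20 uM; a lower number here means a weaker effect, a higher number a stronger effect of the compound at the concentration tested. Compound 1 `COc1cccc(-c2nc3ccc(N4CCCCC4)cc3c(=O)[nH]2)c1OC` gives 0%, compound 3 `CCN(CC)c1ccc2nc(-c3ccccc3N(C)C)[nH]c(=O)c2c1` gives 0%, and compound 2 `Cc1cccc(-c2nc3ccc(C)cc3c(=O)[nH]2)c1` gives 12.7%. On these numbers compound 2 stands highest: its gap to compound 1 and its gap to compound 3 are each beyond the usual scatter, so compound 2 is the only one of the three with a measurable effect at the concentration tested, even though that effect is modest.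

Compound 4 `Cc1ccc2nc(-c3cccc(C(F)(F)F)c3)[nH]c(=O)c2c1` has not yet been measured in this assay. It derives from compound 2 by a single change: trifluoromethyl in place of methyl on an aromatic carbon, sitting on an aromatic carbon of a six-membered aromatic ring of carbon only, meta to a large group. Going by the values given here, no pair of measured compounds that differ in one place is available in this set, so the size of such a step cannot be read from data of this kind.

Given the low level of compound 2 and the lack of a comparable step, the number for compound 4 is expected to stay close to that of compound 2, with a change of a number 0.7 percentage points lower from compound 2 to compound 4 (within the scatter) expected to lie within the scatter in either direction. The estimate for compound 4 is therefore 12%, with a range from 0% to 30%.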

Compound 4, a percentage reported as inhibition, at one concentration (the size of the read-out at that concentration, not a potency): 4.2%
Beside the measured number, compound 4's estimate is 7.8 percentage points above it; the measured number falls inside the stated range.
By their numbers in this assay, from the lowest: compounds 1, 3, 4 and 2 (each within the scatter of the next, the first and the last beyond it).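

In this assay, going by these compounds alone, the exchange of methyl for trifluoromethyl on an aromatic carbon, meta to a large group, provides the first step that can be read at a single place: a number 8.5 percentage points lower from compound 2 to compound 4 (within the scatter). This aromatic carbon therefore takes trifluoromethyl, with its 4 heavy atoms, in place of methyl, with its 1 heavy atom, without a step beyond the scatter, so this change gives no evidence that the read-out depends on which of the two groups sits here. No measurement on either group or on this change bears on the result, so the step stands without an explanation.

From the compounds shown here alone, whether an amine, a carboxylic acid or a nitrile on this same aromatic carbon would give a step beyond the scatter remains open, as does the outcome with a longer chain there. Within the data shown here, the other methyl of compound 2 has no single-place step of its own, and a read-out at one concentration gives no potency for either compound 2 or compound 4.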